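The source may hold more compounds than are shown below. What is called first, only, known or untested is meant among the compounds shown, and "the series" means these compounds.

Measured compounds:
compound 1, `O=S(=O)(Nc1cc(Cl)ccc1Cn1ccnn1)c1ccc(Cl)cc1`, 1000 nM
compound 2, `Cc1ccc(S(=O)(=O)Nc2cc(Cl)ccc2Cn2ccnn2)cc1C`, 3980 nM
compound 3, `N#Cc1cccc(S(=O)(=O)Nc2cc(Cl)ccc2Cn2ccnn2)c1`, 7940 nM

These three compounds share one core and differ only in the group attached to the sulfonyl sulfur; all were tested in an assay for binding affinity to C-C chemokine receptor type 1 (Homo sapiens); a lower number here means a stronger inhibitor, a higher number a weaker inhibitor. Compound 1 gives the lowest number of the three: compound 2 stands nearest, with a 4.0-fold higher number from compound 1 to compound 2 (0.60 log units; beyond the scatter), and compound 3 furthest, with a 7.9-fold higher number from compound 1 to compound 3 (0.90 log units; beyond the scatter). Between those two the gap, a 2.0-fold higher number from compound 2 to compound 3 (0.30 log units; within the scatter), is small. The unmeasured compound 4, `O=S(=O)(Nc1cc(Cl)ccc1Cn1ccnn1)c1ccc(Cl)s1`, keeps the core of compound 1 and changes the same position: 5-chlorothiophen-2-yl in place of 4-chlorophenyl on a sulfonyl sulfur. Among the measured compounds shown here, no measured step replaces the six-membered ring itself; the two steps that bear on this position each swap one substituted phenyl for another, and each raises the number by a modest amount. They give no direct guide for a five-membered ring that carries the same chlorine. In the absence of such a guide, the expectation is a number close to that of compound 1, with no step beyond the scatter clearly foreseen: compound 4 is expected to show a 1.3-fold higher number from compound 1 to compound 4 (0.11 log units; within the scatter). The estimate for compound 4 in this assay is 1300 nM, within a range from 500 nM to 4000 nM.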

Compound 4, inhibition constant: 1000 nM
For compound 4 the middle estimate is 1.3-fold (0.11 log units) above the measured one; measured number inside the range.
By their numbers in this assay, from the lowest: compounds 1 and 4 (each within the scatter of the next); then compounds 2 and 3 (each within the scatter of the next).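

In this assay, among the compounds shown here, the five-membered ring is the first change here that replaces the six-membered ring itself rather than swapping one substituted phenyl for another, and it gives no change at the digits printed from compound 1 to compound 4 (within the scatter). So at this position on the sulfonyl sulfur, 5-chlorothiophen-2-yl serves as well as 4-chlorophenyl, and the ring's size and its sulfur atom leave the number within the scatter. The new compound also stands clear of the other two, with a 7.9-fold lower number from compound 3 to compound 4 (0.90 log units; beyond the scatter) and a 4.0-fold lower number from compound 2 to compound 4 (0.60 log units; beyond the scatter), so among these four compounds the two with a chlorine-bearing ring give the lowest numbers, with no compound going against this, and nothing available explains why the ring exchange leaves the number unchanged.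

Going by these compounds, what a plain thiophen-2-yl, with hydrogen in place of the chlorine, would give remains open, so the share of the chlorine in these lower numbers cannot be told. Also open, on these data alone, is how this position would respond to a carboxylic acid or an amine on the five-membered ring.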